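Series notes: methylsulfanyl added to compound 2

The source may hold more compounds than are shown below. What is called first, only, known or untested is meant among the compounds shown, and "the series" means these compounds.

Compound 2 `Cc1nsc2c1ncn2[C@@H]1O[C@H](CO)[C@@H](O)[C@@H]1O` gives in a functional assay on KB cells (Homo sapiens) for antiproliferative activity (a lower number here means a stronger inhibitor, a higher number a weaker inhibitor), only a limit of the assay, > 100000 nM. Compound 1 `CSc1nc2c(C)nsc2n1[C@H]1C[C@H](O)[C@@H](CO)O1`, which already carries a methylsulfanyl group on a different sugar, likewise reaches only a limit, > 100000 nM. Both values shown therefore sit at the limit of > 100000 nM in this assay, at which 2 of the 2 values shown sit. Compound 3 `CSc1nc2c(C)nsc2n1[C@@H]1O[C@H](CO)[C@@H](O)[C@@H]1O` differs from compound 2 by methylsulfanyl in place of hydrogen on an aromatic carbon. Within the data shown here, no measured step is at hand; because both values shown sit at the limit of > 100000 nM in this assay, at which 2 of the 2 values shown sit, the expected step is a step that the limit leaves unreadable from compound 2 to compound 3, nothing beyond the scatter in this assay. Compound 3 is estimated at 200000 nM, within 50000 nM to 1000000 nM, most probably reported as a limit only.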

Compound 3, half-maximal inhibitory concentration: > 100000 nM
Compound 3 was reported as a limit; the forecaster's own chance of this, stated with the estimate: 85%; the middle value is on the limit's open side.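

No step from compound 2 or compound 1 to compound 3 can be read, because all three compounds stop at the same limit: the limit of > 100000 nM in this assay, at which 3 of the 3 values shown sit.

As far as these compounds go, whether methylsulfanyl or hydroxy in place of hydrogen shifts activity in this assay remains open.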